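The source may report more compounds than this note shows. Statements on the series, on what has been measured and on what is new or still open speak of the compounds shown alone.

Working notes on the sulfur-substituted series sharing one core.

Compound 1 `CCSc1n[nH]c(-n2[se]c3ccccc3c2=O)n1` gives 10000 nM in a functional assay on SMMC-7721 cells (Homo sapiens) for antiproliferative activity, read by CCK-8 assay, with a stated time of 48 h; on this read-out lower numbers stand for stronger inhibition and higher numbers for weaker inhibition. Compound 2 `CC(C)CSc1n[nH]c(-n2[se]c3ccccc3c2=O)n1` gives 35000 nM in this assay. Compound 3 `O=c1c2ccccc2[se]n1-c1nc(SCc2ccc(Cl)cc2)n[nH]1` gives 33900 nM in this assay. On these three numbers compound 1 stands lowest, and both moves away from it go the same way: a 3.5-fold higher number from compound 1 to compound 2 (0.54 log units; beyond the scatter) and a 3.4-fold higher number from compound 1 to compound 3 (0.53 log units; beyond the scatter). Between the two larger groups there is no separation, since a 1.0-fold lower number from compound 2 to compound 3 (0.01 log units; within the scatter).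

Compound 4 `CC(C)Sc1n[nH]c(-n2[se]c3ccccc3c2=O)n1` is the next step from compound 1, and the change is methyl in place of hydrogen on a saturated chain carbon bound to a saturated chain carbon and a sulfur; read one bond further out, the ethylsulfanyl of compound 1 becomes isopropylsulfanyl. The two steps that bear on this are those from compound 1 to compound 2 and from compound 1 to compound 3, where each enlargement of the group on the saturated chain carbon bound to the sulfur carried the number up by a modest but real amount. The change to compound 4 is smaller than either, a single carbon added. For compound 4 the expectation in this assay is therefore a rise in the number, smaller than the two seen steps and close to the edge of the scatter, as a 2.0-fold higher number from compound 1 to compound 4 (0.30 log units; within the scatter). The estimated value for compound 4 is 20000 nM, within 9000 nM to 45000 nM.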

Compound 4, half-maximal inhibitory concentration: 6010 nM
For compound 4 the middle estimate is 3.3-fold (0.52 log units) above the measured one; the measured number lies below the stated range.
By their numbers in this assay, from the lowest: compounds 4 and 1 (each within the scatter of the next); then compounds 3 and 2 (each within the scatter of the next).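

In this assay, methyl in place of hydrogen on a saturated chain carbon bound to a saturated chain carbon and a sulfur leaves the number within the scatter (a 1.7-fold lower number from compound 1 to compound 4 (0.22 log units; within the scatter)), so the change from ethylsulfanyl to isopropylsulfanyl does not bring the rise seen with the enlargements in compound 2 and compound 3. Compound 4 thus goes against any reading that a larger group on the sulfur simply carries the number up, and it separates clearly from both of those compounds: isopropyl in place of isobutyl gives (a 5.8-fold lower number from compound 2 to compound 4 (0.77 log units; beyond the scatter)), and isopropyl in place of 4-chlorobenzyl gives (a 5.6-fold lower number from compound 3 to compound 4 (0.75 log units; beyond the scatter)). No supporting measurement is available to account for this difference among the sulfur substituents.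

The compounds shown leave open whether a cyclopropyl or tert-butyl group on the sulfur would stay level with compound 4, and whether an unbranched longer chain such as n-butyl would follow isobutyl in compound 2. They also leave open how a terminal hydroxyl or amine on the sulfur chain would read in this assay.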